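Swapping a Pyrrole Amide for a Methylphenyl Amide

The compounds below may be only part of what the source reports. "The series", "measured", "known", "first", "only" and "open" are said of these compounds alone.

Measured so far:
compound 1 `CCN1CCN(c2cc(C)c3cc(NC(=O)c4ccccc4OC)ccc3n2)CC1` gives 13200 nM
compound 2 `CCN1CCN(c2cc(C)c3cc(NC(=O)c4ccc(Cl)c(Cl)c4)ccc3n2)CC1` gives 1380 nM
compound 3 `CCN1CCN(c2cc(C)c3cc(NC(=O)c4ccc[nH]4)ccc3n2)CC1` gives 14700 nM

These three compounds share one core and differ only in the aromatic group attached to the carbonyl of the amide. In a functional assay on MCF7 cells (Homo sapiens) for antiproliferative activity, read by MTT assay, with a stated time of 72 h (a higher number here means a weaker inhibitor, a lower number a stronger inhibitor), compound 3 gives the highest number of the three, but this says little against compound 1, since a 1.1-fold higher number from compound 1 to compound 3 (0.05 log units; within the scatter). The only clear separation is to compound 2: an 11-fold higher number from compound 2 to compound 3 (1.03 log units; beyond the scatter). So far, then, a phenyl carrying two chlorines has given a much lower number than either the methoxy-bearing phenyl or the pyrrole.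

Compound 4 `CCN1CCN(c2cc(C)c3cc(NC(=O)c4cccc(C)c4)ccc3n2)CC1` is the next member of the series. 3-methylphenyl in place of 1H-pyrrol-2-yl on a carbonyl carbon

Among the compounds with values here, two measured steps bear on this change. The step of a 1.1-fold higher number from compound 1 to compound 3 (0.05 log units; within the scatter) shows that a pyrrole and a methoxy-bearing phenyl are indistinguishable here, while an 11-fold higher number from compound 2 to compound 3 (1.03 log units; beyond the scatter) shows that a chlorinated phenyl gives a far lower number. A phenyl carrying a single methyl has not been measured. A lowering of the number is expected for compound 4, smaller than the step seen with compound 2, so that a 3.3-fold lower number from compound 3 to compound 4 (0.51 log units; beyond the scatter). The expected value for compound 4 is 4500 nM, with a range from 1500 nM to 13000 nM.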

Compound 4, half-maximal inhibitory concentration: 7800 nM
Estimate against measurement, compound 4: 1.7-fold (0.24 log units) below, within the range that was stated.
By their numbers in this assay, from the lowest: compound 2; then compounds 4, 1 and 3 (each within the scatter of the next).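

In this assay, the 1H-pyrrol-2-yl group carries one hydrogen-bond donor and the 3-methylphenyl group none, yet exchanging one for the other on the carbonyl carbon stays within the scatter: a 1.9-fold lower number from compound 3 to compound 4 (0.28 log units; within the scatter). The comparison with the methoxy-bearing phenyl reads the same way, a 1.7-fold lower number from compound 1 to compound 4 (0.23 log units; within the scatter), so compound 1, compound 3 and compound 4 cannot be told apart here, despite their different rings and substituents. Within the data shown here, a six-membered carbon ring alone therefore does not give the low number of compound 2, since a 5.7-fold higher number from compound 2 to compound 4 (0.75 log units; beyond the scatter), a gap beyond the scatter that leaves 3,4-dichlorophenyl as the only group of the four that stands apart.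

The compounds shown leave open whether a single chlorine on the phenyl would be enough or both are needed, and how a phenyl bearing an amine or a carboxylic acid would compare. No measurement shown here explains why the dichlorinated ring differs from the other three.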